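The source may hold more compounds than are shown below. What is called first, only, known or untested is meant among the compounds shown, and "the series" means these compounds.

In a functional assay on KB cells (Homo sapiens) for antiproliferative activity, read by sulforhodamine B assay, with a stated time of 3 days (on this read-out lower numbers stand for an effect already at smaller amounts and higher numbers for an effect only at larger amounts of compound), compound 1 `CCCC1=C(OC)C(CCC)(CCC)C(=O)/C(=C(O)\C=C\c2ccccc2)C1=O` gives 4.6 uM and compound 2 `CCCC1=C(OCCC(C)C)C(CCC)(CCC)C(=O)/C(=C(O)\C=C\c2ccccc2)C1=O` gives 10.6 uM on the same scale. Compound 3 `COC1=C(CC=C(C)C)C(=O)/C(=C(O)/C=C/c2ccccc2)C(=O)C1(CC=C(C)C)CC=C(C)C` gives 13.3 uM in the same test. Compound 2 therefore lies within the usual scatter of compound 3, but beyond that scatter from compound 1.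

The next compound to consider is compound 4 `CCCOC1=C(CCC)C(=O)/C(=C(O)/C=C/c2ccccc2)C(=O)C1(CCC)CCC`, which has a propoxy group where compound 2 has an isopentyloxy group. The change is methyl in place of isopropyl on a saturated chain carbon, two bonds along the chain from an oxygen on an unsaturated carbon and in words it is methyl in place of isopropyl on a saturated chain carbon, two bonds along the chain from an oxygen on an unsaturated carbon.

Among the measured compounds shown here, only one measured step alters the chain on this same oxygen. It shows a 2.3-fold higher number from compound 1 to compound 2 (0.36 log units; beyond the scatter) and is modest, and a single step is thin evidence for any trend. Compound 4 keeps part of the chain added in that step, so only part of the step is expected to be reversed. The expected result in this assay is a 1.5-fold lower number from compound 2 to compound 4 (0.18 log units; within the scatter) and this small move towards a lower number may not clear the scatter. For compound 4 the estimate is 7 uM with an expected range from 3.5 uM to 14 uM in this test.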

Compound 4, concentration for half-maximal effect: 2.7 uM
Compound 4: the middle estimate sits 2.6-fold (0.41 log units) above what was measured; measured number below the stated range.
By their numbers in this assay, from the lowest: compounds 4 and 1 (each within the scatter of the next); then compounds 2 and 3 (each within the scatter of the next).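

In this assay, shortening the isopentyloxy group to propoxy gives a 3.9-fold lower number from compound 2 to compound 4 (0.59 log units; beyond the scatter), so the earlier rise in the number does not persist once the chain is cut back part of the way. Going the other way along this series, from the short methoxy group to propoxy, gives a 1.7-fold lower number from compound 1 to compound 4 (0.23 log units; within the scatter), which means the chain on this oxygen can grow to propoxy without a clear change in the read-out. Among these three compounds, therefore, the number does not climb steadily with chain size: only compound 2, with its isopentyloxy group, stands apart from the other two, and nothing available here explains why the propoxy and isopentyloxy chains differ in this way.

As far as these compounds go, it remains open whether the higher number of compound 2 goes with the length of its chain or with its branch, a question that a straight pentyloxy chain on the same oxygen could help to settle. It is also unknown how this position would respond to a chain carrying an amine or a carboxylic acid, since every group on this oxygen shown so far is made of carbon and hydrogen alone.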